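A few compounds are considered here, and "the series" means these few. Any claim that something is new, unique, unknown or untested is made for them only; others in the source may bear on it.

Measured compounds:
compound 1, `COc1cc(O)c2c(c1)O[C@H](c1ccc(O)cc1)C/C2=N\Nc1ccccc1`, >= 11300 nM
compound 2, `COc1cc(O)c2c(c1)O[C@H](c1ccc(O)cc1)C/C2=N\Nc1ccc(Br)cn1`, 4300 nM
compound 3, `COc1ccc([C@@H]2C/C(=N\Nc3ccccc3)c3c(O)cc(OC)cc3O2)cc1`, >= 11300 nM

In a functional assay on L5178Y cells (Mus musculus) for inhibition, read by MTT assay, with a stated time of 24 h (on this read-out higher numbers stand for weaker inhibition and lower numbers for stronger inhibition), compound 1 gives only a limit of the assay, >= 11300 nM. Compound 2 gives 4300 nM in this assay, and the step of an at least 2.6-fold lower number from compound 1 to compound 2 (0.41 log units; beyond the scatter) follows one change, (5-bromopyridin-2-yl in place of phenyl on an amine nitrogen). Compound 3 also sits at a limit of the assay, >= 11300 nM. Its core differs from the core of compound 1 by methyl in place of hydrogen on an oxygen on an aromatic ring, and the step that the two limits leave unreadable from compound 1 to compound 3 cannot be sized. Compound 4, `COc1ccc([C@@H]2C/C(=N\Nc3ccc(Br)cn3)c3c(O)cc(OC)cc3O2)cc1`, is not yet measured; it carries the same change relative to compound 3, (5-bromopyridin-2-yl in place of phenyl on an amine nitrogen), at a place described in the same words. Because compound 1 sits at the limit (the limit of >= 11300 nM in this assay, at which 2 of the 3 values shown sit), the first step is known only as a bound. For compound 4 a step of similar kind is expected, an at least 2.2-fold lower number from compound 3 to compound 4 (0.35 log units; beyond the scatter). Compound 4 is estimated at 5000 nM, ranging from 2500 nM to 12000 nM.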

Compound 4, half-maximal inhibitory concentration: 8000 nM
Compound 4: middle estimate off by 1.6-fold (0.20 log units), on the low side, and the stated range covers the measured number.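

On the core of compound 3, 5-bromopyridin-2-yl in place of phenyl on the amine nitrogen gives an at least 1.4-fold lower number from compound 3 to compound 4 (0.14 log units; that floor lies within the scatter) in this assay, a floor that does not by itself show a real gain on this core. Set beside the step on the core of compound 1, the change cannot be said to carry over either equally or unequally: the same change on two cores in this assay, an at least 2.6-fold lower number (0.41 log units; beyond the scatter) from compound 1 to compound 2 and an at least 1.4-fold lower number (0.14 log units; that floor lies within the scatter) from compound 3 to compound 4; the limit leaves it open whether they differ. With 5-bromopyridin-2-yl present, methyl in place of hydrogen on an oxygen on an aromatic ring gives a 1.9-fold higher number from compound 2 to compound 4 (0.27 log units; within the scatter), so these two compounds do not separate in this assay.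

The compounds shown leave open how large either step truly is. They also leave open whether a pyridine ring without bromine, or a phenyl ring carrying bromine, would give a value clear of the limit: the limit of >= 11300 nM in this assay, at which 2 of the 4 values shown sit.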